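The compounds below may be only part of what the source reports. "The series", "measured", "known", "first", "only" and "open" are said of these compounds alone.

Among the measured compounds shown here, compound 1 `FC(F)(F)c1cccc(-c2nc3cnc(Nc4ccccn4)cc3[nH]2)c1` gives 47% in an ADME assay on microsomes from liver (Mus musculus) for metabolic stability, read by LC-MS, with a stated time of 30 min, tested at 0.1 uM (on this read-out lower numbers stand for a less stable compound and higher numbers for a more stable compound), the second highest of the three numbers measured so far. Compound 2 `FC(F)(F)c1cccc(-c2nc3cnc(Nc4ccncn4)cc3[nH]2)c1` gives 89% in this assay, while compound 3 `FC(F)(F)c1cccc(-c2nc3cnc(Nc4cnccn4)cc3[nH]2)c1` gives 7%. Compound 4 `FC(F)(F)c1cccc(-c2nc3cnc(Nc4cccnn4)cc3[nH]2)c1` has not yet been measured; it differs from compound 1 by pyridazin-3-yl in place of pyridin-2-yl on a nitrogen on an aromatic ring. Two measured steps also replace the pyridin-2-yl of compound 1, and they point in opposite directions: a number 42 percentage points higher from compound 1 to compound 2 (beyond the scatter) and a number 40 percentage points lower from compound 1 to compound 3 (beyond the scatter). Between those two replacements the gap is a number 82 percentage points lower from compound 2 to compound 3 (beyond the scatter). A large step in this assay is therefore expected for compound 4, but its direction cannot be read from these three compounds. Compound 4 is estimated at 45%, within a wide range from 10% to 85%, which means an expected step of a number 2 percentage points lower from compound 1 to compound 4 (within the scatter).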

Compound 4, percent of the compound remaining: 51%
Beside the measured number, compound 4's estimate is 6 percentage points below it; low and high end bracket the measured number.
By their numbers in this assay, from the lowest: compound 3; then compounds 1 and 4 (each within the scatter of the next); then compound 2.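

In this assay, the second ring nitrogen of pyridazin-3-yl leaves the number unchanged relative to pyridin-2-yl, with a number 4 percentage points higher from compound 1 to compound 4 (within the scatter). Yet the three rings with two nitrogens remain far apart, with a number 44 percentage points higher from compound 3 to compound 4 (beyond the scatter) and a number 38 percentage points lower from compound 2 to compound 4 (beyond the scatter), so at this position the count of ring nitrogens alone does not decide the result. Nothing available explains these differences. Still open, as far as these compounds go, is how a plain phenyl ring or a triazine, with three ring nitrogens, would behave on the same nitrogen.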